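From a Hydroxyethyl Chain to a Hydroxycyclohexyl Ring

A few compounds are considered here, and "the series" means these few. Any claim that something is new, unique, unknown or untested is made for them only; others in the source may bear on it.

Compound 1 `COc1ccc(-c2c(-c3ccc(OC)cc3)n(Cc3ccccc3)c3ncn(CCCO)c(=N)c23)cc1` gives 0.36 h in an ADME assay on microsomes from liver (Mus musculus, strain CD1) for metabolic stability, read by LC-MS, using NADPH, with a stated time of 60 min; on this read-out higher numbers stand for a longer-lived compound and lower numbers for a shorter-lived compound.
Compound 2 `Cc1c(C)n(Cc2ccccc2)c2ncn(CCCO)c(=N)c12` gives 2 h in this assay.
Compound 3 `COc1ccc(-c2c(-c3ccc(OC)cc3)n(Cc3ccccc3)c3ncn(CCO)c(=N)c23)cc1` gives 1.22 h in this assay.

Among the measured compounds shown here, of the three numbers so far, compound 3 holds the second highest. Its gap to compound 2 lies within the scatter, so the two cannot be told apart on this read-out. For the measured compounds named here, its gap to compound 1 is the only step that changes one place at a time: a 3.4-fold higher number from compound 1 to compound 3 (0.53 log units; beyond the scatter).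

Compound 4 `COc1ccc(-c2c(-c3ccc(OC)cc3)n(Cc3ccccc3)c3ncn([C@@H]4CCCC[C@H]4O)c(=N)c23)cc1` is the next step, and it differs from compound 3 only in this way: 2-hydroxycyclohexyl in place of 2-hydroxyethyl on an aromatic nitrogen.

Going by the values given here, the step from compound 1 to compound 3 is the one measurement that touches the group on this ring nitrogen, and it shows that shortening the chain there gave a modest rise beyond the scatter. Compound 2 differs from the others at several places at once, so it says nothing direct about the ring nitrogen substituent. Among the compounds with values here, no measured compound carries a ring at this position, so the direction for compound 4 is open. A change of this size is expected to stay close to the scatter: a 1.2-fold lower number from compound 3 to compound 4 (0.09 log units; within the scatter). Compound 4 is therefore estimated at 1 h, with a range from 0.4 h to 2.5 h.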

Compound 4, half-life: 0.487 h
Beside the measured number, compound 4's estimate is 2.1-fold (0.31 log units) above it; measured number inside the range.
By their numbers in this assay, from the lowest: compounds 1 and 4 (each within the scatter of the next); then compounds 3 and 2 (each within the scatter of the next).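

Placing a ring on this aromatic nitrogen does not keep the longer half-life that the 2-hydroxyethyl group gives in this assay: on the shared core, the change to 2-hydroxycyclohexyl gives a 2.5-fold lower number from compound 3 to compound 4 (0.40 log units; beyond the scatter) and so removes the gain seen with the shorter chain. Set against the 3-hydroxypropyl group, the same ring gives a 1.4-fold higher number from compound 1 to compound 4 (0.13 log units; within the scatter) and cannot be told apart from it on this read-out, so among these three groups on this core, only 2-hydroxyethyl stands clear of the other two. Nothing in the data shown explains why the ring and the 2-hydroxyethyl group differ in this way.

The compounds shown leave open whether the lower number goes with the ring itself or simply with a larger group, a question that an open hexyl chain carrying a hydroxy group could help to settle. They also leave open whether the hydroxy group matters on the cyclohexyl ring, as a plain cyclohexyl group or an amine in its place would show, and whether the other arrangements at the two defined stereocentres behave alike.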